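From compound 3 to its 4-chlorophenyl analogue

The source may report more compounds than this note shows. Statements on the series, on what has been measured and on what is new or still open speak of the compounds shown alone.

Of the compounds shown here, three have numbers so far in a functional assay on HepG2 cells (Homo sapiens) for inhibition, read by MTT assay, with a stated time of 48 h; on this read-out higher numbers stand for weaker inhibition of growth and lower numbers for stronger inhibition of growth. Compound 1 `COc1ccc(C(=O)N2N=C(c3ccccc3)CC2c2cn(C)c3ccccc23)cn1` gives 3130 nM, compound 2 `COc1ccc2c(c1)c(C1CC(c3ccccc3)=NN1C(=O)c1cccnc1)cn2C` gives 5110 nM and compound 3 `COc1ccc2c(c1)c(C1CC(c3ccccc3)=NN1C(=O)c1ccc(OC)nc1)cn2C` gives 1330 nM. Compound 3 thus holds the lowest number of the three, and its gaps to the other two lie beyond the scatter.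

The next structure is compound 4 `COc1ccc2c(c1)c(C1CC(c3ccc(Cl)cc3)=NN1C(=O)c1ccc(OC)nc1)cn2C`, which differs from compound 3 by chloro in place of hydrogen on an aromatic carbon, phenyl to 4-chlorophenyl.

Going by the values given here, only two measured steps offer any guide, each of them methoxy in place of hydrogen on an aromatic carbon: a 2.4-fold lower number from compound 1 to compound 3 (0.37 log units; beyond the scatter) and a 3.8-fold lower number from compound 2 to compound 3 (0.58 log units; beyond the scatter). Both are modest. Among the compounds with values here, neither touches the phenyl, and no chloro step has been measured. These steps therefore give a rough scale and no direction for chloro.

A small step is expected in this assay, probably no larger than those two, with only a weak lean towards a lower number. The expected step is a 1.3-fold lower number from compound 3 to compound 4 (0.12 log units; within the scatter). Compound 4 is estimated at 1000 nM, with an expected range from 400 nM to 2500 nM.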

Compound 4, concentration for 50% growth inhibition: 2080 nM
For compound 4 the middle estimate is 2.1-fold (0.32 log units) below the measured one; low and high end bracket the measured number.
By their numbers in this assay, from the lowest: compounds 3, 4, 1 and 2 (each within the scatter of the next, the first and the last beyond it).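

In this assay, phenyl to 4-chlorophenyl is the only substitution on this ring among the compounds shown, and it gives a 1.6-fold higher number from compound 3 to compound 4 (0.19 log units; within the scatter), so compound 3 and compound 4 cannot be told apart. Going by these compounds alone, this is the first sign that this aromatic carbon, para to a large group, accepts a chlorine atom without a step that can be read in this assay. The two methoxy steps elsewhere on the molecule, a 2.4-fold lower number from compound 1 to compound 3 (0.37 log units; beyond the scatter) and a 3.8-fold lower number from compound 2 to compound 3 (0.58 log units; beyond the scatter), both lie beyond the scatter, whereas the chloro step stays within it, and no measurement at hand bears on why the result falls as it does.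

From the compounds shown here alone, one substituent on this ring gives little basis for a trend, so it remains open whether an amine, a carboxylic acid or a trifluoromethyl group at the same carbon would also stay within the scatter of compound 3. Going by these compounds, it also remains open whether the same chloro step would read alike on the cores of compound 1 and compound 2, which lack one or other of the methoxy groups of compound 3.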